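Replacing 4-methoxyphenyl with 2-fluorophenyl on the shared core

The source may report more compounds than this note shows. Statements on the series, on what has been measured and on what is new or still open speak of the compounds shown alone.

In an ADME assay on THP-1 cells (Homo sapiens) for cytotoxicity, read by flow cytometry and propidium iodide staining, with a stated time of 72 h (on this read-out higher numbers stand for weaker inhibition and lower numbers for stronger inhibition), compound 1 `COc1c(-c2ccccc2)oc2ccc(NC(C)=O)cc2c1=O` gives > 125000 nM, which is a limit and not a number. Compound 2 `COc1ccc(-c2oc3ccc(NC(C)=O)cc3c(=O)c2OC)cc1` gives > 50000 nM, which is also only a limit. Going by the values given here, the one measured step, a step that the two limits leave unreadable from compound 1 to compound 2, therefore has no readable size. Compound 3 `COc1c(-c2ccccc2F)oc2ccc(NC(C)=O)cc2c1=O` carries 2-fluorophenyl in place of 4-methoxyphenyl on an aromatic carbon. Among the compounds with values here, with a step that the two limits leave unreadable from compound 1 to compound 2 as the only guide, no step beyond the scatter is expected in this assay, in either direction. The expected change is a step that the limit leaves unreadable from compound 2 to compound 3. Compound 3 is estimated at 80000 nM, with an expected range from 25000 nM to 200000 nM.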

Compound 3, half-maximal inhibitory concentration: > 125000 nM
Compound 3 gave a limit, no number; the forecaster's own chance of this, stated with the estimate: 75%; middle value at least 1.5-fold (0.19 log units) away from the limit.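

Compound 3 gives > 125000 nM, which is a limit and not a number. Going by these compounds alone, no step among compound 1, compound 2 and compound 3 can be read. The compounds shown leave open what half-maximal inhibitory concentration any of them has in this assay.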